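The source may hold more compounds than are shown below. What is called first, only, known or untested is meant among the compounds shown, and "the series" means these compounds.

Compound 1, with the structure `Cc1ccc(-c2ccccc2OC(C)C2=NCCN2)cc1`, was tested in a functional assay on CHO cells for agonist activity at Alpha-2B adrenergic receptor (Homo sapiens) (a lower number here means a smaller maximal response, a higher number a larger maximal response), and gave < 0.3, which is a limit of the measurement rather than a number. A second compound, compound 2, with the structure `CC(Oc1ccccc1-c1ccccc1[N+](=O)[O-])C1=NCCN1`, was tested in the same way; compound 2 gave < 0.3, again a limit and not a number. Both results therefore sit at the same boundary, as shown by the limit of < 0.3 in this assay, at which 2 of the 2 values shown sit, so compound 1 cannot be placed above or below compound 2 on the numbers shown. Among the measured compounds shown here, no two measured compounds differ in only one place, so no measured step is available.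

The next compound, compound 3, has the structure `Cc1cccc(-c2ccccc2OC(C)C2=NCCN2)c1`. It differs from compound 1 by 3-methylphenyl in place of 4-methylphenyl on an aromatic carbon. For the measured compounds named here, since the two compounds share the same atoms joined differently, and nothing among the measured compounds indicates that moving the methyl group changes the response, no step beyond the usual scatter is expected. The step from compound 1 to compound 3 is expected to be a step that the limit leaves unreadable from compound 1 to compound 3. Compound 3 is therefore estimated to give 0.2, with a range from 0.05 to 0.4, most likely again reported only as a limit.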

Compound 3, intrinsic activity: the largest response reached, as a fraction of the reference agonist's: < 0.3
Compound 3 gave a limit, no number; the forecaster's own chance of this, stated with the estimate: 70%; the middle value is on the limit's open side.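

Compound 1 and compound 3 cannot be compared, even though they differ only in 3-methylphenyl replacing 4-methylphenyl, because each result in this assay is a limit and not a number: the limit of < 0.3 in this assay, at which 3 of the 3 values shown sit. The compounds shown leave open how large the true maximal response of each one is, and whether any change to the shared core would give a measurable number.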